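The source may report more compounds than this note shows. Statements on the series, on what has been measured and on what is new or still open speak of the compounds shown alone.

Measured compounds in a functional assay on HCT-15 cells (Homo sapiens) for cytotoxicity, read by sulforhodamine B assay, with a stated time of 72 h; on this read-out higher numbers stand for weaker inhibition of growth and lower numbers for stronger inhibition of growth:
compound 1 `CC(=O)N1c2ccccc2CCC1C(=O)Nc1ccccc1O`: 54500 nM
compound 2 `CC(=O)N1c2ccccc2CCC1C(=O)Nc1cc(C(F)(F)F)cc(C(F)(F)F)c1`: a limit of the assay, > 70000 nM
compound 3 `CCCC(=O)N1c2ccccc2CCC1C(=O)Nc1ccccc1C(F)(F)F`: a limit of the assay, > 70000 nM

Compound 3 stands at the limit of this assay and gives no number of its own. Among the three compounds only compound 1 gives a number, and the other two sit where the assay stops reporting (the limit of > 70000 nM in this assay, at which 2 of the 3 values shown sit). Within the data shown here, no step between measured compounds can be computed from this set.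

Compound 4 `O=C(Nc1ccccc1C(F)(F)F)C1CCc2ccccc2N1C(=O)c1ccccc1Cl` is the one still to be measured in this assay. The change from compound 3 to compound 4 is 2-chlorophenyl in place of propyl on a carbonyl carbon. Among the measured compounds shown here, nothing among the measured compounds covers a change at this carbonyl, so no measured step can guide the expectation. The step expected from compound 3 to compound 4 is an at least 1.1-fold lower number from compound 3 to compound 4 (0.06 log units; that floor lies within the scatter), not beyond the scatter, with no clear direction. Compound 4 is estimated at 60000 nM, within 20000 nM to 100000 nM, most likely reported again as a limit.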

Compound 4, concentration for 50% growth inhibition: 4220 nM
Compound 4: middle estimate off by 14-fold (1.15 log units), on the high side; the whole stated range lies above it.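

In this assay, the carbonyl carbon on the amide-type nitrogen in a ring proves to be a place where the substituent matters: 2-chlorophenyl in place of propyl gives an at least 16-fold lower number from compound 3 to compound 4 (1.21 log units; beyond the scatter). Among these compounds, the size of this step is only a floor, because compound 3 carries a limit of the assay and not a number: the limit of > 70000 nM in this assay, at which 2 of the 4 values shown sit. The earlier compounds held no step at this carbonyl, so this first reading of the place rests on a single pair.

On these data alone, whether the ring or the chlorine carries the step stays open; plain phenyl and cyclohexyl on this carbonyl would separate the two. Also open, as far as these compounds go, is whether 2-chlorophenyl gives a similar step when the other amide of the shared core carries the group found in compound 1.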